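From trifluoromethyl to acetyl: a step behind limits

The compounds below may be only part of what the source reports. "The series", "measured", "known", "first", "only" and "open" are said of these compounds alone.

Values in an ADME assay on MDCK cells (Canis lupus familiaris) for cytotoxicity, read by MTT assay, with a stated time of 24 h (on this read-out higher numbers stand for lower toxicity in this test and lower numbers for higher toxicity in this test), each one a limit:
compound 1 `N#CCCN(Cc1cccs1)S(=O)(=O)c1ccc(F)cc1`: > 205000 nM
compound 2 `N#CCCN(Cc1cccs1)S(=O)(=O)c1ccc(C#N)cc1`: > 201000 nM
compound 3 `N#CCCN(Cc1cccs1)S(=O)(=O)c1ccc(C(F)(F)F)cc1`: > 178000 nM

Compound 3 has only a limit, > 178000 nM, and gives no number to step from. Compound 4 `CC(=O)c1ccc(S(=O)(=O)N(CCC#N)Cc2cccs2)cc1` differs from it by acetyl in place of trifluoromethyl on an aromatic carbon. The bearing steps are the other exchanges on that aromatic carbon: a step that the two limits leave unreadable from compound 1 to compound 2, a step that the two limits leave unreadable from compound 1 to compound 3 and a step that the two limits leave unreadable from compound 2 to compound 3. None of the three has a readable size, so no step beyond the usual scatter is expected in this assay, in either direction. The expected step is a step that the limit leaves unreadable from compound 3 to compound 4. Compound 4 is estimated at 190000 nM, within a range of 120000 nM to 260000 nM, and is expected to read again as a limit.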

Compound 4, half-maximal cytotoxic concentration: > 191000 nM
Compound 4 gave a limit, no number; the forecaster's own chance of this, stated with the estimate: 85%; middle value at least 1.0-fold (0.00 log units) away from the limit.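

Among the compounds shown here, compound 4, like compounds 1, 2 and 3, reads only as a limit in this assay, so no step between any of them can be read. The compounds shown leave open whether exchanging the group on the aromatic carbon shifts this read-out at all.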